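Swapping the aryl group for cyclopentyl on the core

The source may report more compounds than this note shows. Statements on the series, on what has been measured and on what is new or still open speak of the compounds shown alone.

Compound 3 `CC(C)c1ccccc1-c1nc(NCc2ccc(-c3cccnc3)cc2)c2ccccc2n1` gives 180 nM in an assay on a protein complex for inhibition of ubiquitin carboxyl-terminal hydrolase 1/WD repeat-containing protein 48 (Homo sapiens), read by fluorescence (on this read-out higher numbers stand for weaker inhibition and lower numbers for stronger inhibition), the lowest of the three numbers recorded. Compound 2 `FC(F)(F)c1cc(-c2ccc(CNc3nc(-c4ccccc4C(F)(F)F)nc4ccccc34)cc2)ccn1` gives 4900 nM and compound 1 `N#Cc1ccc(CNc2nc(-c3ccccc3C(F)(F)F)nc3ccccc23)cc1` gives 5700 nM, and both of these stand beyond the scatter away from compound 3. For the measured compounds named here, the only measured step, a 1.2-fold lower number from compound 1 to compound 2 (0.07 log units; within the scatter), concerns a different part of the molecule and so bears only loosely on what follows.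

Compound 4 `c1cncc(-c2ccc(CNc3nc(C4CCCC4)nc4ccccc34)cc2)c1` differs from compound 3 in one place: cyclopentyl in place of 2-isopropylphenyl on an aromatic carbon. Going by the values given here, no measured pair isolates this change. Compounds 1 and 2 carry a different group of this kind and also differ from compound 3 elsewhere, so their values show only that the set spans a wide range. Without a direct precedent, a loss of potency beyond the scatter is taken as the likelier outcome, though its size is uncertain. Compound 4 is expected to give 800 nM, with a range from 150 nM to 4000 nM. The expected step is a 4.4-fold higher number from compound 3 to compound 4 (0.65 log units; beyond the scatter).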

Compound 4, half-maximal inhibitory concentration: "not active" (no number reported)
The entry for compound 4 holds no number; no gap can be computed for the estimate.
By their numbers in this assay, from the lowest: compound 3; then compounds 2 and 1 (each within the scatter of the next).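

For the compounds shown here, compound 4 is recorded as not active in this assay, without a number, so no step from compound 3 can be read. Nothing shown here accounts for this result. The compounds shown leave open how far cyclopentyl falls short of 2-isopropylphenyl on the shared core.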